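The compounds below may be only part of what the source reports. "The series", "measured", "known", "first", "only" and "open" are said of these compounds alone.

Compound 1 `COc1cccc(NC(=S)NC2CC(C)(C)Oc3ccc(Br)cc32)c1` gives 87000 nM in a functional assay on T98G cells (Homo sapiens) for inhibition, read by MTT assay, with a stated time of 72 h (on this read-out higher numbers stand for weaker inhibition and lower numbers for stronger inhibition), and is the weaker of the two compounds with a number in hand. That is the highest value recorded here, while compound 3 `CC1(C)CC(NC(=O)Nc2ccccc2)c2cc(Cl)ccc2O1` gives 34000 nM in this assay, a lower number by a margin beyond the usual scatter. Compound 2 `CCOC(=O)NC1CC(C)(C)Oc2ccc(Cl)cc21` was also examined in this assay, where its entry is "not determined" (no result reported), so no result was reported for it. Compound 4 `COc1ccc(NC(=S)NC2CC(C)(C)Oc3ccc(Br)cc32)cc1` has not yet been measured and differs from compound 1 in a single place: 4-methoxyphenyl in place of 3-methoxyphenyl on an amide-type nitrogen. Within the data shown here, no measured pair shows the effect of such a change, so the expected step is small and could go either way, likely within the scatter; the estimated step is a 1.2-fold lower number from compound 1 to compound 4 (0.09 log units; within the scatter). Compound 4 is therefore expected to give about 70000 nM in this assay, in the range 25000 nM to 200000 nM.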

Compound 4, half-maximal inhibitory concentration: 33000 nM
Estimate against measurement, compound 4: 2.1-fold (0.33 log units) above; the measured number falls inside the stated range.
By their numbers in this assay, from the lowest: compounds 4 and 3 (each within the scatter of the next); then compound 1.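

In this assay, among these compounds, 4-methoxyphenyl in place of 3-methoxyphenyl on an amide-type nitrogen gives a 2.6-fold lower number from compound 1 to compound 4 (0.42 log units; beyond the scatter) and provides the first measured step at this place. With the same atoms joined differently, the change of position alone is enough to shift the number by a modest amount. No measurement shown offers an explanation for this step.

From the compounds shown here alone, it remains open how an ethoxy group, an amine or a carboxylic acid in place of the methoxy group would read in this assay. Going by these compounds, it is also open whether the same step would appear on a different core.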